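This account rests on a few compounds, and the source may have more. Where it says the series, first, only, none or still open, it means among the compounds named here.

Compound 1 `COc1ccc(Cl)cc1CN[C@H]1[C@H](C(C)(C)C)[C@@H](C(=O)O)N(C(=O)C2CCCCC2)[C@H]1c1ccccc1` — 241 nM
Compound 2 `COc1ccc(C(C)C)cc1CN[C@H]1[C@H](C(C)(C)C)[C@@H](C(=O)O)N(C(=O)C2CCCCC2)[C@H]1c1ccccc1` — 188 nM
Compound 3 `COc1ccc(C23CC4CC42C3)cc1CN[C@H]1[C@H](C(C)(C)C)[C@@H](C(=O)O)N(C(=O)C2CCCCC2)[C@H]1c1ccccc1` — 190 nM

The three compounds share one core and were tested in an assay on HBE cells for positive allosteric modulation of Cystic fibrosis transmembrane conductance regulator variant F508del (Homo sapiens); on this read-out lower numbers stand for an effect already at smaller amounts and higher numbers for an effect only at larger amounts of compound. The span of their numbers is narrow: compound 2 sits at the low end of it, yet its gaps to the others are small, with a 1.3-fold lower number from compound 1 to compound 2 (0.11 log units; within the scatter) and a 1.0-fold higher number from compound 2 to compound 3 (0.00 log units; within the scatter), and the remaining pair shows a 1.3-fold lower number from compound 1 to compound 3 (0.10 log units; within the scatter). All three steps stay within the scatter, so the group on that aromatic carbon, whether chloro, isopropyl or the six-carbon ring system, leaves the read-out essentially unchanged.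

Compound 4 `COc1ncc(C(C)(C)C)cc1CN[C@H]1[C@H](C(C)(C)C)[C@@H](C(=O)O)N(C(=O)C2CCCCC2)[C@H]1c1ccccc1` has not yet been measured in this assay. Relative to compound 2 it carries a group of 12 heavy atoms (10 carbon, 1 nitrogen, 1 oxygen; one six-membered aromatic ring with 1 hetero atom) in place of a group of 11 heavy atoms (10 carbon, 1 oxygen; one six-membered aromatic ring of carbon only), on a saturated chain carbon bound to an amine nitrogen. Only part of that change has a precedent: the swap of isopropyl for a larger carbon group, seen in a 1.0-fold higher number from compound 2 to compound 3 (0.00 log units; within the scatter), moved nothing. For the measured compounds named here, the ring nitrogen, however, has no counterpart among the measured compounds, so no step speaks to it. On that basis he expects the step of a 1.1-fold higher number from compound 2 to compound 4 (0.03 log units; within the scatter) to stay within the scatter, with no direction favoured. His estimate for compound 4 in this assay is 200 nM, within a range from 90 nM to 450 nM.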

Compound 4, half-maximal effective concentration: 107 nM
Beside the measured number, compound 4's estimate is 1.9-fold (0.27 log units) above it; the range from low to high includes it.
By their numbers in this assay, from the lowest: compounds 4, 2, 3 and 1 (each within the scatter of the next, the first and the last beyond it).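

In this assay, the six-membered aromatic ring with 1 hetero atom is accepted at this place, on a saturated chain carbon bound to an amine nitrogen: the change gives a 1.8-fold lower number from compound 2 to compound 4 (0.24 log units; within the scatter), so the ring nitrogen and the accompanying change of carbon group do not carry the read-out outside the scatter relative to the 5-isopropyl-2-methoxyphenyl compound. The comparison with the chloro compound gives a 2.3-fold lower number from compound 1 to compound 4 (0.35 log units; beyond the scatter), a modest step and the first in this set to lie beyond the scatter, whereas the earlier swaps of the aromatic substituent all stayed within it. Nothing available explains this result or links it to any measured property of the entering group.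

The compounds shown leave open how much of the step belongs to the ring nitrogen and how much to tert-butyl in place of isopropyl, since both differ at once and only a ring-nitrogen compound carrying isopropyl or chloro would separate them. They also leave open how this ring would behave with a nitrile, an amine or a trifluoromethyl group in place of tert-butyl.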